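Compound 3 to compound 4: a side-chain exchange

The compounds below may be only part of what the source reports. "The series", "measured", "known", "first", "only" and "open" are said of these compounds alone.

In a functional assay on MOLT-4 cells (Homo sapiens) for inhibition, read by MTT assay, with a stated time of 4 days (on this read-out higher numbers stand for weaker inhibition and lower numbers for stronger inhibition), compound 1 `COc1cc(NC(C)CCCNC(=O)NNC(=O)NCCO)c2ncccc2c1` gives > 250000 nM, which is a limit. Compound 2 `COc1cc(NC(C)CCCNC(=O)NNC(=O)NC(CO)(CO)CO)c2ncccc2c1` gives > 250000 nM, also a limit. Compound 3 `COc1cc(NC(C)CCCNC(=O)NNC(=O)N(CCO)CCO)c2ncccc2c1` gives > 250000 nM, again a limit. Among the measured compounds shown here, the series so far rests on (the limit of > 250000 nM in this assay, at which 3 of the 3 values shown sit). The measured steps, a step that the two limits leave unreadable from compound 1 to compound 2, a step that the two limits leave unreadable from compound 1 to compound 3 and a step that the two limits leave unreadable from compound 2 to compound 3, have no readable size and give no measure for the next change.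

Compound 4 `COc1cc(NC(C)CCCNC(=O)Nc2ccc(Cl)c(C(F)(F)F)c2)c2ncccc2c1` differs from compound 3 as follows: 4-chloro-3-(trifluoromethyl)phenyl in place of (bis(2-hydroxyethyl)carbamoyl)amino on an amide-type nitrogen. For the measured compounds named here, no measured step makes this exchange. With compound 3 at the limit of > 250000 nM, a readable value for compound 4 can only lie toward stronger inhibition in this assay. The expected change is an at least 12-fold lower number from compound 3 to compound 4 (1.09 log units; beyond the scatter). For compound 4 the estimated value is 20000 nM, with an expected range of 4000 nM to 100000 nM.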

Compound 4, half-maximal inhibitory concentration: 3400 nM
Compound 4: the middle estimate sits 5.9-fold (0.77 log units) above what was measured; measured number outside the range, below it.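

In this assay, the substituent on the amide-type nitrogen proves able to move the read-out, with an at least 73-fold lower number from compound 3 to compound 4 (1.86 log units; beyond the scatter), an at least 73-fold lower number from compound 2 to compound 4 (1.86 log units; beyond the scatter) and an at least 73-fold lower number from compound 1 to compound 4 (1.86 log units; beyond the scatter). All three steps start from a limit, so each gives only a minimum size, and the steps among compound 1, compound 2 and compound 3 cannot be read. Compound 4 is the only compound here with a readable value: the limit of > 250000 nM in this assay, at which 3 of the 4 values shown sit.

Which part of 4-chloro-3-(trifluoromethyl)phenyl carries the step remains open. An unsubstituted phenyl, or a phenyl carrying only chlorine or only trifluoromethyl, would separate the ring from its substituents.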